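This account rests on a few compounds, and the source may have more. Where it says the series, first, only, none or still open, it means among the compounds named here.

The account starts from compound 1, whose structure is `CCCS(=O)(=O)Nc1cccc2c1CCC2c1ncc[nH]1`. In a functional assay on CHO cells for agonist activity at Alpha-1B adrenergic receptor (Homo sapiens), read by FLIPR and calcium flux (a higher number here means that more compound is needed for the effect, a lower number that less compound is needed), compound 1 gives only a limit, > 10000 nM, not a number. Compound 2, `Clc1ccc2c(c1-c1ccn[nH]1)CCC2c1ncc[nH]1`, stands beside it, and in this assay compound 2 likewise gives only a limit, > 10000 nM. Among the measured compounds shown here, both values sit at the limit of > 10000 nM in this assay, at which 2 of the 2 values shown sit, so no measured step between them can be given, and neither compound stands above or below the other on what is known. Compound 3, `Cn1cc(-c2cccc3c2CCC3c2ncc[nH]2)cn1`, has not yet been measured in this assay. It differs from compound 1 by 1-methyl-1H-pyrazol-4-yl in place of (propylsulfonyl)amino on an aromatic carbon. For the measured compounds named here, with no measured step to lean on, and with two limits as the only evidence, no change beyond the scatter is expected, and the step is expected to be a number no higher from compound 1 to compound 3 (the limit leaves the size open) in this assay. For compound 3 the estimate in this assay is 10000 nM, within a range from 3000 nM to 30000 nM.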

Compound 3, half-maximal effective concentration: > 10000 nM
Compound 3: only a limit was reported; the forecaster's own chance of this, stated with the estimate: 75%; the middle value lies on the limit itself.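

Compound 1 and compound 3 both give only limits in this assay, so no step between them can be read: the limit of > 10000 nM in this assay, at which 3 of the 3 values shown sit.

The compounds shown leave open how far apart compound 1 and compound 3 truly lie, and which change to the shared core, if any, would bring a readable number in this assay.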